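The compounds below may be only part of what the source reports. "The series", "measured", "known", "first", "only" and "open" are said of these compounds alone.

Compound 1 `O=c1cc(/C=N\c2ccccc2O)c2c(OCc3ccccc3)cc(OCc3ccccc3)cc2o1` gives 33100 nM in a functional assay, read by spectrophotometry, with a stated time of 5 min; a higher number here means a weaker inhibitor, a lower number a stronger inhibitor.
Compound 2 `N/N=C\c1cc(=O)oc2cc(OCc3ccccc3)ccc12` gives 131000 nM in this assay.
Compound 3 `O=c1cc(-c2nc3ccccc3[nH]2)c2ccc(OCc3ccccc3)cc2o1` gives 146000 nM in this assay.

Compound 3 stands at the highest number of the three, with compound 2 the nearest, a gap that lies within the scatter, and compound 1 the furthest, a gap that lies beyond it. The unmeasured compound 4 `O=c1cc(/C=N\c2ccccc2O)c2ccc(OCc3ccccc3)cc2o1` is reached from compound 3 by a group of 9 heavy atoms (7 carbon, 1 nitrogen, 1 oxygen; one six-membered aromatic ring of carbon only) in place of a group of 9 heavy atoms (7 carbon, 2 nitrogen; one five-membered aromatic ring with 2 hetero atoms, one six-membered aromatic ring of carbon only), on an aromatic carbon. Among the measured compounds shown here, only one measured step alters this same position: a 1.1-fold higher number from compound 2 to compound 3 (0.05 log units; within the scatter), which stayed within the scatter. That step swapped one group for another at the position, as the present change does, but neither of its two groups is the one that enters here. Compound 1 carries the entering group on a core that bears a second substituent absent from compound 4, and no step between compound 1 and compound 4 is shown, so its value is only a hint. Compound 4 is therefore expected to shift modestly toward a lower number, a 2.4-fold lower number from compound 3 to compound 4 (0.39 log units; beyond the scatter), landing at an estimated 60000 nM, with a range from 20000 nM to 180000 nM.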

Compound 4, half-maximal inhibitory concentration: 469000 nM
Estimate against measurement, compound 4: 7.8-fold (0.89 log units) below; measured number outside the range, above it.
By their numbers in this assay, from the lowest: compound 1; then compounds 2 and 3 (each within the scatter of the next); then compound 4.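

In this assay, this position proved sensitive to the group it carries: the earlier exchange, a 1.1-fold higher number from compound 2 to compound 3 (0.05 log units; within the scatter), stayed within the scatter, whereas the group entering here moved the number beyond it, with a 3.2-fold higher number from compound 3 to compound 4 (0.51 log units; beyond the scatter) and a 3.6-fold higher number from compound 2 to compound 4 (0.55 log units; beyond the scatter). The latter step puts 2-hydroxyphenyl in place of amino on a double-bonded nitrogen, and both steps run toward a weaker inhibitor. The entering group alone did not carry the lower number of compound 1, since putting hydrogen in place of benzyloxy on an aromatic carbon gives a 14-fold higher number from compound 1 to compound 4 (1.15 log units; beyond the scatter), the largest step shown.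

The compounds shown leave open whether a carboxylic acid or a simple amine at this position would fall on either side of these values, and whether the added benzyloxy would lower the number with 1H-benzimidazol-2-yl in place. No measurement here explains any of these steps.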